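The source may hold more compounds than are shown below. What is called first, only, known or untested is meant among the compounds shown, and "the series" means these compounds.

The measured compounds:
Compound 1, `Cc1cc(Cl)c2oc(N3CCN(C)CC3)nc2c1`, gives 6.22 in a functional assay on ileum (strain Hartley) for agonist activity at 5-hydroxytryptamine receptor 3A (Cavia porcellus); on this read-out higher numbers stand for higher potency (the scale is a negative logarithm) and lower numbers for lower potency.
Compound 2, `COc1cc(C)cc2nc(N3CCN(C)CC3)oc12`, gives 6.13 in this assay.
Compound 3, `CN1CCN(c2nc3cccc(Cl)c3o2)CC1`, gives 5.5 in this assay.

Compound 4, `COc1cccc2nc(N3CCN(C)CC3)oc12`, has not yet been measured in this assay. It differs from compound 3 by a single change: methoxy in place of chloro on an aromatic carbon. The same kind of change has already been made once, from compound 1 to compound 2: methoxy in place of chloro on an aromatic carbon. That step was a number 0.09 log units lower from compound 1 to compound 2 (within the scatter). The two settings are not identical, since the place in compound 1 is also meta to a methyl group, which compound 3 lacks; the two cores differ by hydrogen in place of methyl on an aromatic carbon, a step of a number 0.72 log units lower from compound 1 to compound 3 (beyond the scatter). Because the step of a number 0.09 log units lower from compound 1 to compound 2 (within the scatter) stayed within the scatter, the step expected in this assay from compound 3 to compound 4 is a number 0.05 log units lower from compound 3 to compound 4 (within the scatter), likewise small. Compound 4 is therefore estimated at 5.45 in this assay, with a plausible range from 4.9 to 6.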

Compound 4, negative logarithm of the half-maximal effective concentration: < 4
Compound 4: no number, only a limit; the forecaster's own chance of this, stated with the estimate: 5%; at least 1.45 log units between middle value and limit.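

In this assay compound 4 gives < 4, which is a limit of the assay and not a number. Methoxy in place of chloro therefore does not carry from one core to the other, with a number at least 1.50 log units lower from compound 3 to compound 4 (beyond the scatter): the same change on two cores in this assay, a number 0.09 log units lower (within the scatter) from compound 1 to compound 2 and a number at least 1.50 log units lower (beyond the scatter) from compound 3 to compound 4, at least 1.41 log units apart, beyond the scatter of two such steps Hydrogen in place of methyl likewise depends on the group already present, with a number at least 2.13 log units lower from compound 2 to compound 4 (beyond the scatter), and these four compounds show that the two changes do not simply add up, but not why, nor how large the true gap is: the same change on two cores in this assay, a number 0.72 log units lower (beyond the scatter) from compound 1 to compound 3 and a number at least 2.13 log units lower (beyond the scatter) from compound 2 to compound 4, at least 1.41 log units apart, beyond the scatter of two such steps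

The compounds shown leave open whether other groups in place of chloro on the core of compound 3, such as fluoro or ethoxy, would follow methoxy or chloro. On these data alone, it also remains open whether ethyl or another group in place of the methyl would keep the methoxy compound as close to its chloro partner as compound 2 is to compound 1.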